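The source may report more compounds than this note shows. Statements on the series, on what has been measured and on what is new or still open speak of the compounds shown alone.

Compound 1 `Cc1ccc(C(=O)Nc2cn3ncnc3c(O[C@H]3CCN(C(=O)CC(C(F)(F)F)C(F)(F)F)[C@@H](C)C3)c2C)cn1` gives 10 mL.min-1.g-1 in an ADME assay on microsomes from liver (Homo sapiens) for metabolic stability; a lower number here means slower removal, a higher number faster removal of the compound. Compound 2 `Cc1ccc(C(=O)Nc2cn3ncnc3c(CN3CCN(C(=O)CCC(F)(F)F)[C@@H](C)C3)c2C)cn1` is reported in this assay only as a limit, < 10 mL.min-1.g-1, and so it stands at the low end of what the assay resolves (the limit of < 10 mL.min-1.g-1 in this assay, at which 1 of the 2 values shown sits). Compound 3 `Cc1ccc(C(=O)Nc2cn3ncnc3c(CN3CCN(C(=O)C(C)C)[C@@H](C)C3)c2C)cn1` differs from compound 2 in one place: isopropyl in place of 3,3,3-trifluoropropyl on a carbonyl carbon. Among the compounds with values here, no measured step between compounds is available to size this change, so the expectation for the step from compound 2 to compound 3, an at least 1.2-fold higher number from compound 2 to compound 3 (0.07 log units; that floor lies within the scatter), is no change beyond the scatter. Compound 3 is accordingly estimated at 12 mL.min-1.g-1, within 6 mL.min-1.g-1 to 30 mL.min-1.g-1.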

Compound 3, intrinsic clearance in microsomes: 240 mL.min-1.g-1
Compound 3: middle estimate off by 20-fold (1.30 log units), on the low side, and the stated range ends below it.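

In this assay, within the data shown here, isopropyl in place of 3,3,3-trifluoropropyl on a carbonyl carbon gives an at least 24-fold higher number from compound 2 to compound 3 (1.38 log units; beyond the scatter), the first measured step at this position, and it shows that this one change can move the read-out a long way. The full size of the step cannot be fixed because compound 2 is reported only as a limit: the limit of < 10 mL.min-1.g-1 in this assay, at which 1 of the 3 values shown sits.

The compounds shown do not tell what in the change produces the step. From the compounds shown here alone, it remains open whether a plain propyl chain or a cyclopropyl group at this place would read like compound 2 or like compound 3.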